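This account rests on a few compounds, and the source may have more. Where it says the series, first, only, none or still open, it means among the compounds named here.

Compound 1, `CCCCCCCCCc1ccc(OP(=O)(O)OC[C@H]2O[C@@H](n3cc(F)c(=O)[nH]c3=O)C[C@@H]2OC(=O)c2ccccc2)cc1`, in a functional assay on Caco-2 cells (Homo sapiens) for cytotoxicity, read by MTT assay, with a stated time of 48 h; on this read-out lower numbers stand for stronger inhibition and higher numbers for weaker inhibition: 20400 nM
Compound 2, `O=C(O[C@H]1C[C@H](n2cc(F)c(=O)[nH]c2=O)O[C@@H]1COP(=O)(O)Oc1cccnc1)c1ccccc1`: 2500 nM
Compound 3, `C[n+]1cccc(OP(=O)([O-])OC[C@H]2O[C@@H](n3cc(F)c(=O)[nH]c3=O)C[C@@H]2OC(=O)c2ccccc2)c1`: 1380 nM

Among these three numbers compound 3 gives the lowest, but compound 2 sits within the scatter of it, so the two cannot be told apart; compound 1 lies clearly higher than both. Compound 4, `CCOC(=O)C[n+]1cccc(OP(=O)([O-])OC[C@H]2O[C@@H](n3cc(F)c(=O)[nH]c3=O)C[C@@H]2OC(=O)c2ccccc2)c1`, has not yet been measured. It differs from compound 3 in one place: ethoxycarbonyl in place of hydrogen on a saturated chain carbon bound to an aromatic nitrogen. Among the measured compounds shown here, the only measured step that touches the same part of the molecule is a 1.8-fold lower number from compound 2 to compound 3 (0.26 log units; within the scatter), and that step was small. For the measured compounds named here, no measured step adds anything onto the carbon bound to the aromatic nitrogen itself, so the data give no direct guide to the present change. Going by the values given here, with the rest of the molecule unchanged and the nearest precedent small, no step beyond the scatter is expected; the estimated step is a 1.1-fold higher number from compound 3 to compound 4 (0.04 log units; within the scatter). Compound 4 is therefore expected to give about 1500 nM, with a likely range from 500 nM to 4500 nM.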

Compound 4, half-maximal inhibitory concentration: 2620 nM
Beside the measured number, compound 4's estimate is 1.7-fold (0.24 log units) below it; the measured number falls inside the stated range.
By their numbers in this assay, from the lowest: compounds 3, 2 and 4 (each within the scatter of the next); then compound 1.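

In this assay, a 1.9-fold higher number from compound 3 to compound 4 (0.28 log units; within the scatter) goes with ethoxycarbonyl in place of hydrogen on a saturated chain carbon bound to an aromatic nitrogen. Among the compounds shown here, this is the first measured change at that carbon, and it shows that ethoxycarbonyl can be added there without the number leaving the usual scatter, so this change cannot be told apart from no change at all. Nothing measured on these compounds offers an explanation for this result.

From the compounds shown here alone, it remains open whether a carboxylic acid in place of the ethyl ester, an amine or a longer chain on this carbon would also stay within the scatter. A single step also cannot show whether ethoxycarbonyl would give a similar result on a different compound.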